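Notes on inverting two ring stereocentres of compound 2

The source may report more compounds than this note shows. Statements on the series, on what has been measured and on what is new or still open speak of the compounds shown alone.

Measured in a functional assay on HeLa cells (Homo sapiens) for cytotoxicity, read by WST assay, with a stated time of 48 h; on this read-out higher numbers stand for weaker inhibition and lower numbers for stronger inhibition:
compound 1 `COc1ccc(/C=C/C[C@H]2C[C@@H]([C@@H](O)c3ccc(OC)c(OC)c3)CO[C@@H]2c2ccc(OC)c(OC)c2)cc1`: 12200 nM
compound 2 `COc1cccc(/C=C/C[C@@H]2C[C@@H]([C@@H](O)c3ccc(OC)c(OC)c3)CO[C@H]2c2ccc(OC)c(OC)c2)c1`: 16400 nM
compound 3 `COc1ccc(CCC[C@@H]2C[C@@H]([C@@H](O)c3ccc(OC)c(OC)c3)CO[C@H]2c2ccc(OC)c(OC)c2)cc1OC`: 35700 nM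

Compound 2 (16400 nM) lies within the scatter of compound 1 (12200 nM), and only compound 3 stands apart from it. Compound 4 `COc1cccc(/C=C/C[C@H]2C[C@@H]([C@@H](O)c3ccc(OC)c(OC)c3)CO[C@@H]2c2ccc(OC)c(OC)c2)c1` is still unmeasured. Against compound 2 the change is the two compounds have the same atoms and bonds and differ only in configuration as drawn: 2 of 5 stereo elements differ; a stereocentre at a saturated ring carbon is drawn R in compound 2 and S in compound 4; a stereocentre at a saturated ring carbon is drawn R in compound 2 and S in compound 4. Both centres sit at saturated ring carbons, and the atoms and bonds stay the same.

One measured step is available: a 2.2-fold higher number from compound 2 to compound 3 (0.34 log units; beyond the scatter). It places 2-(3,4-dimethoxyphenyl)ethyl where 2-(3-methoxyphenyl)ethenyl stood, so it offers only a sense of scale, a modest one. Among the compounds with values here, no measured step isolates a change of configuration, so the size of this change remains unknown. The three values span a narrow range, and the expectation rests on that narrowness, with compound 3 at 35700 nM marking its upper end. No shift beyond the scatter is therefore expected in this assay, and no direction is favoured. The estimated step is a 1.1-fold lower number from compound 2 to compound 4 (0.04 log units; within the scatter). The range is kept wide, as the data hold no direct test. For compound 4 the expected value is 15000 nM, with an estimated range of 6500 nM to 35000 nM.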

Compound 4, half-maximal inhibitory concentration: 14000 nM
Estimate against measurement, compound 4: 1.1-fold (0.03 log units) above, within the range that was stated.
By their numbers in this assay, from the lowest: compounds 1, 4 and 2 (each within the scatter of the next); then compound 3.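

Within the data shown here, this is the first step that reads configuration alone: the fact that compounds 2 and 4 differ only in the configuration as drawn. In this assay, inverting the two saturated ring stereocentres gives a 1.2-fold lower number from compound 2 to compound 4 (0.07 log units; within the scatter), so within these compounds the two drawn configurations cannot be told apart on this read-out. With the configuration of compound 1 held, 3-methoxyphenyl in place of 4-methoxyphenyl gives a 1.1-fold higher number from compound 1 to compound 4 (0.06 log units; within the scatter), which separates the methoxy placement from the configuration, two changes that were combined in the earlier comparison of compound 1 with compound 2, and this step likewise stays within the scatter.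

Still open, as far as these compounds go, is whether the same inversion would read alike on the 2-(3,4-dimethoxyphenyl)ethyl chain of compound 3, and whether inverting either ring stereocentre alone would behave as the pair does. Also open is how the series would respond to a more different group, such as an amine or a carboxylic acid in place of the methoxy on the 3-methoxyphenyl, since every compound shown carries only methoxy groups on its aromatic rings.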